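Replacing furan-2-yl with trifluoromethyl on a shared core

The source may report more compounds than this note shows. Statements on the series, on what has been measured and on what is new or still open speak of the compounds shown alone.

In a functional assay on L1210 cells (Mus musculus) for antiproliferative activity, read by cell counting, with a stated time of 48 h (a higher number here means a weaker inhibitor, a lower number a stronger inhibitor), compound 1 `C#C[C@@]1(O)[C@@H](CO)O[C@@H](n2cc(F)c3c(N)ncnc32)[C@@H]1O` gives 35 nM, while compound 2 `C#C[C@@]1(O)[C@@H](CO)O[C@@H](n2cc(-c3ccco3)c3c(N)ncnc32)[C@@H]1O` gives 30000 nM, the higher of the two numbers and so the weaker inhibitor. Compound 3 `C#C[C@@]1(O)[C@@H](CO)O[C@@H](n2cc(C(F)(F)F)c3c(N)ncnc32)[C@@H]1O` keeps the shared core and changes one group: trifluoromethyl in place of furan-2-yl on an aromatic carbon. Trifluoromethyl takes the place of furan-2-yl on the aromatic carbon that holds fluoro in compound 1.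

For the measured compounds named here, only one measured step bears on this change: an 860-fold higher number from compound 1 to compound 2 (2.93 log units; beyond the scatter), which is large and beyond the scatter. It shows that this carbon can matter greatly, but trifluoromethyl has not been tested there, so it offers only a rough guide. A large move back towards a lower number seems likely, though probably not all the way. The expected step is a 75-fold lower number from compound 2 to compound 3 (1.88 log units; beyond the scatter). For compound 3, the estimated value is 400 nM, with an expected range from 40 nM to 4000 nM.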

Compound 3, half-maximal inhibitory concentration: 110 nM
The estimate for compound 3 lay 3.6-fold (0.56 log units) above the measured number; the range from low to high includes it.
By their numbers in this assay, from the lowest: compound 1; then compound 3; then compound 2.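

In this assay, trifluoromethyl in place of furan-2-yl gives a 270-fold lower number from compound 2 to compound 3 (2.44 log units; beyond the scatter), so the large loss seen with furan-2-yl does not extend to every group other than fluoro on this aromatic carbon. Trifluoromethyl in place of fluoro gives only a 3.1-fold higher number from compound 1 to compound 3 (0.50 log units; beyond the scatter), a modest step that is still beyond the scatter, so this carbon accepts a change from fluoro at a small cost, with fluoro keeping the lower number. No data shown here explain these differences.

From the compounds shown here alone, with only fluoro, trifluoromethyl and furan-2-yl to compare, it remains open whether the ring of furan-2-yl is what matters or some other feature of that group. Going by these compounds, how a phenyl ring, a nitrile or an amine would behave on this carbon also remains open.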